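Tetrahydronaphthalene aryl sulfones: amine substituent change

This account rests on a few compounds, and the source may have more. Where it says the series, first, only, none or still open, it means among the compounds named here.

Measured so far in an assay on isolated protein for displacement of a labelled ligand from 5-hydroxytryptamine receptor 6 (Homo sapiens); a higher number here means a weaker inhibitor, a lower number a stronger inhibitor:
- compound 1 `N#Cc1cccc(S(=O)(=O)c2ccc3c(c2)CCC[C@H]3C=N)c1` gives 0.501 nM
- compound 2 `NC[C@@H]1CCCc2cc(S(=O)(=O)c3cc[nH]c3)ccc21` gives 0.316 nM
- compound 3 `CNS(=O)(=O)NC[C@@H]1CCCc2cc(S(=O)(=O)c3cccc(F)c3)ccc21` gives 1 nM

Compound 3 has the highest number of the three. Its gap to compound 1 lies within the usual scatter, so the two cannot be ordered; its gap to compound 2 lies beyond it, with compound 2 giving the lower number.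

Compound 4 `O=S(=O)(O)CCCNC[C@@H]1CCCc2cc(S(=O)(=O)c3cccc(F)c3)ccc21` has not yet been measured. It differs from compound 3 in a single place: 3-sulfopropyl in place of methylsulfamoyl on an amine nitrogen. Among the compounds with values here, no pair of measured compounds differs in just one place, so there is no prior step to lean on. All three measured compounds sit close together, which suggests the change is tolerated; a step of no more than the scatter is expected, written as a 1.5-fold higher number from compound 3 to compound 4 (0.18 log units; within the scatter). Compound 4 is therefore estimated at 1.5 nM in this assay, within 0.4 nM to 6 nM.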

Compound 4, inhibition constant: 1.26 nM
Estimate against measurement, compound 4: 1.2-fold (0.08 log units) above; low and high end bracket the measured number.
By their numbers in this assay, from the lowest: compounds 2, 1, 3 and 4 (each within the scatter of the next, the first and the last beyond it).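

In this assay, the series gains its first single-place step, a 1.3-fold higher number from compound 3 to compound 4 (0.10 log units; within the scatter), which lies within the scatter. On this amine nitrogen, 3-sulfopropyl and methylsulfamoyl cannot be told apart, even though the entering group has 7 heavy atoms against 5 and no nitrogen. Nothing measured here accounts for this tolerance.

Going by these compounds, it remains open whether the sulfo end of the chain contributes at all. A plain propyl chain or a carboxylic acid on the same nitrogen would test this, as would a longer chain.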